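Solubility notes: trifluoromethoxy position on the aniline nitrogen

This account rests on a few compounds, and the source may have more. Where it says the series, first, only, none or still open, it means among the compounds named here.

Compound 3 `CNC(=O)c1cc(Oc2ccc3nc(Nc4cccc(OC(F)(F)F)c4)ncc3c2)ccn1` carries a 3-(trifluoromethoxy)phenyl on the shared core. In a physicochemical assay for solubility, at pH 7 (a lower number here means a less soluble compound, a higher number a more soluble compound), compound 3 returns only a limit, < 1000 nM. Compound 1 `CNC(=O)c1cc(Oc2ccc3nc(Nc4cccc(Br)c4)ncc3c2)ccn1` likewise gives a limit in this assay, < 1000 nM. Compound 2 `CNC(=O)c1cc(Oc2ccc3nc(Nc4cccc(C(F)(F)F)c4)ncc3c2)ccn1` also sits at a limit in this assay, < 1000 nM. All three share (the limit of < 1000 nM in this assay, at which 3 of the 3 values shown sit), so the steps a step that the two limits leave unreadable from compound 1 to compound 2, a step that the two limits leave unreadable from compound 1 to compound 3 and a step that the two limits leave unreadable from compound 2 to compound 3 give no readable size. Compound 4 `CNC(=O)c1cc(Oc2ccc3nc(Nc4ccc(OC(F)(F)F)cc4)ncc3c2)ccn1` differs from compound 3 by 4-(trifluoromethoxy)phenyl in place of 3-(trifluoromethoxy)phenyl on a nitrogen on an aromatic ring. Within the data shown here, no measured step covers this kind of change, and none of the measured steps has a readable size. Compound 4 is expected to sit near the same limit, 500 nM with a range of 100 nM to 3000 nM. The step that the limit leaves unreadable from compound 3 to compound 4 is estimated to stay within the scatter.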

Compound 4, solubility: < 1000 nM
Compound 4: a limit, no number (the forecaster's own chance of this, stated with the estimate: 75%); the middle value lies beyond the limit too.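

In this assay compound 4 also returns only a limit, < 1000 nM and so its steps from compound 1, compound 2 and compound 3 cannot be read: the limit of < 1000 nM in this assay, at which 4 of the 4 values shown sit. The compounds shown leave open how far apart these four lie in this assay and whether 4-(trifluoromethoxy)phenyl and 3-(trifluoromethoxy)phenyl differ there at all.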